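Working notes on the step to compound 4

The source may hold more compounds than are shown below. What is called first, only, known or untested is meant among the compounds shown, and "the series" means these compounds.

Compound 1 is `COc1nc2c(N)ncnc2n1Cc1ccccc1`; in a functional assay (spleen, spleen) for activation, with Mus musculus as the target (a lower number here means that less compound is needed, a higher number that more compound is needed for the effect), compound 1 gives > 10 uM, which is a limit of the assay and not a number. Compound 2 is `Nc1ncnc2c1nc(I)n2Cc1ccccc1`; in this assay compound 2 gives > 10 uM, again a limit. Compound 3 is `NNc1nc2c(N)ncnc2n1Cc1ccccc1`; in this assay compound 3 gives > 10 uM, also a limit. Compound 3 thus stands only at a limit, and the steps among the measured compounds cannot be sized: a step that the two limits leave unreadable from compound 1 to compound 2, a step that the two limits leave unreadable from compound 1 to compound 3 and a step that the two limits leave unreadable from compound 2 to compound 3 remain unreadable because of the limit of > 10 uM in this assay, at which 3 of the 3 values shown sit. Compound 4 is `Nc1ncnc2c1nc(S)n2Cc1ccccc1`. The change is sulfanyl in place of aminoamino on an aromatic carbon. For the measured compounds named here, none of the measured steps involves a sulfanyl, so none bears directly on this change; the only anchor is the limit at which compound 3 sits. The expected step is therefore a step that the limit leaves unreadable from compound 3 to compound 4 in this assay, with no direction readable from the data. Compound 4 is estimated at 20 uM, within 4 uM to 100 uM, with a real chance that again only a limit is returned.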

Compound 4, minimum effective concentration: 10 uM
Compound 4: the middle estimate sits 2.0-fold (0.30 log units) above what was measured; low and high end bracket the measured number.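

Sulfanyl on the aromatic carbon between two ring nitrogen atoms is the first change in the series to return a number and not a limit: in this assay compound 4 gives 10 uM. Against the earlier compounds, the steps read a number no higher from compound 3 to compound 4 (the limit leaves the size open), a number no higher from compound 2 to compound 4 (the limit leaves the size open) and a number no higher from compound 1 to compound 4 (the limit leaves the size open). These steps give a direction at most, and their sizes stay open because the earlier compounds sit at a limit: the limit of > 10 uM in this assay, at which 3 of the 4 values shown sit.

For the compounds shown here, how far compound 4 actually lies from the earlier compounds remains open, so no gain in potency can be claimed for sulfanyl. Also open, as far as these compounds go, is whether an amine or a longer chain such as ethylsulfanyl on this same carbon would return a number in this assay.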